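A few compounds are considered here, and "the series" means these few. Any claim that something is new, unique, unknown or untested is made for them only; others in the source may bear on it.

Measured so far in an assay for inhibition of RAC-alpha serine/threonine-protein kinase (Homo sapiens), read by HTRF, with a stated time of 1 h; on this read-out lower numbers stand for stronger inhibition and higher numbers for weaker inhibition:

compound 1, `CC(=O)OCC[C@@H]1C[C@@H](c2ccc(F)c(F)c2)[C@H](NC(=O)c2cc(-c3c(Cl)cnn3C)c(Cl)o2)CN1`: 3.4 nM
compound 2, `Cn1ncc(Cl)c1-c1cc(C(=O)N[C@@H]2CN[C@H](CC(N)=O)C[C@H]2c2ccc(Cl)c(Cl)c2)oc1Cl`: 3.24 nM
compound 3, `Cn1ncc(Cl)c1-c1cc(C(=O)N[C@@H]2CN[C@H](CC(O)CO)C[C@H]2c2ccc(F)c(F)c2)oc1Cl`: 3.31 nM

The three numbers sit within the scatter of one another, so compound 2 cannot be set apart from compound 1 or compound 3 on these data; its number is simply one of three indistinguishable readings.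

Compound 4, `CCC[C@@H]1C[C@@H](c2ccc(Cl)c(Cl)c2)[C@H](NC(=O)c2cc(-c3c(Cl)cnn3C)c(Cl)o2)CN1`, is not yet measured. Against compound 2 the change is ethyl in place of carbamoyl on a saturated chain carbon bound to a saturated ring carbon.

Among the measured compounds shown here, only one measured step touches the same place: a 1.0-fold lower number from compound 1 to compound 3 (0.01 log units; within the scatter). That step swapped one group for another at the saturated chain carbon bound to a saturated ring carbon and left the number unchanged. It does not cover the present change, since both of its groups carried hydrogen-bond donors and acceptors, whereas ethyl carries none. For the measured compounds named here, no measured step therefore speaks directly to the removal of carbamoyl. On that basis the expectation for the step is small, leaning if anything toward a higher number: a 1.5-fold higher number from compound 2 to compound 4 (0.19 log units; within the scatter) is expected. Compound 4 is accordingly estimated at 5 nM, within 2 nM to 12 nM.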

Compound 4, half-maximal inhibitory concentration: 10.4 nM
Estimate against measurement, compound 4: 2.1-fold (0.32 log units) below; measured number inside the range.
By their numbers in this assay, from the lowest: compounds 2, 3 and 1 (each within the scatter of the next); then compound 4.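

Among the compounds shown here, at the saturated chain carbon bound to a saturated ring carbon, the number in this assay does respond to the group carried: ethyl in place of carbamoyl gives (a 3.2-fold higher number from compound 2 to compound 4 (0.51 log units; beyond the scatter)), the first step here beyond the scatter. The earlier step at this place (a 1.0-fold lower number from compound 1 to compound 3 (0.01 log units; within the scatter)) had suggested that the position tolerates exchange, but that now holds only for the pair it connects. The effect is modest, and nothing available explains it.

The compounds shown leave open whether an amine or a carboxylic acid on this chain would read like compound 2 or like compound 4. They also leave open whether a longer alkyl chain than propyl would raise the number further, as this change rests on a single pair.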